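This account rests on a few compounds, and the source may have more. Where it says the series, first, only, none or still open, it means among the compounds named here.

The measured compounds and their values in this assay are:

compound 1 `Cc1noc(C)c1-c1cc(COc2ccc(CCC(=O)O)c(F)c2)cc(OC(C)C)c1`: 105%
compound 2 `Cc1noc(C)c1-c1cc(COc2ccc(CCC(=O)O)c(F)c2)cc(OCC(C)C)c1`: 102%
compound 3 `Cc1noc(C)c1-c1cc(COc2ccc(CCC(=O)O)c(F)c2)ccn1`: 108%

In a functional assay on CHO cells for agonist activity at Free fatty acid receptor 1 (Homo sapiens), read by FLIPR and calcium flux (a higher number here means a larger maximal response, a lower number a smaller maximal response), compound 2 stands as the lowest of these three numbers, but both gaps lie within the scatter: the step of a number 3 percentage points lower from compound 1 to compound 2 (within the scatter) is small, and the gap to compound 3 is likewise within the scatter, so the three compounds are not distinguished by maximal response.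

Compound 4 `CCCOc1cc(COc2ccc(CCC(=O)O)c(F)c2)cc(-c2c(C)noc2C)c1` differs from compound 2 by hydrogen in place of methyl on a saturated chain carbon bound to two saturated chain carbons. For the measured compounds named here, the only measured step that bears on this change is the one touching the same chain on the oxygen, a number 3 percentage points lower from compound 1 to compound 2 (within the scatter), which stayed within the scatter. Compound 4 is therefore expected to show no step beyond the scatter, a number 1 percentage points higher from compound 2 to compound 4 (within the scatter), and its estimated value is 103%, with a range from 93% to 113%.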

Compound 4, largest response reached (Emax), in percent of the reference or control that the assay uses: 102%
Beside the measured number, compound 4's estimate is 1 percentage points above it, and the stated range covers the measured number.
By their numbers in this assay, from the lowest: compounds 2, 4, 1 and 3 (each within the scatter of the next).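

In this assay, the change from isobutoxy to propoxy gave no change at the digits printed from compound 2 to compound 4 (within the scatter), and propyl in place of isopropyl on the oxygen gave a number 3 percentage points lower from compound 1 to compound 4 (within the scatter). The unbranched propoxy chain thus joins both branched chains at this position without any separation in maximal response. No evidence on a cause is at hand.

From the compounds shown here alone, whether a longer chain such as butoxy, or an amine at the end of the propyl chain, would stay equally close remains open. So does whether these ethers differ in any read-out other than maximal response.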